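Amide Swap on a Pyrazole Statin Core: Compound 3 to 4

The compounds below may be only part of what the source reports. "The series", "measured", "known", "first", "only" and "open" are said of these compounds alone.

The series shares one core, seen in compound 1 `CC(C)c1c(C(=O)N2CCCC2c2ccccc2)nn(-c2ccc(F)cc2)c1OC[C@@H](O)C[C@@H](O)CC(=O)O`, where a carbonyl carbon on the core carries a 2-phenylpyrrolidin-1-yl amide. In a functional assay on L6 cells (Rattus norvegicus) for inhibition (a higher number here means a weaker inhibitor, a lower number a stronger inhibitor), compound 1 gives 4340 nM. Compound 2 `CC(C)c1c(C(=O)N2CCC[C@H](c3ccccc3)C2)nn(-c2ccc(F)cc2)c1OC[C@@H](O)C[C@@H](O)CC(=O)O` carries 3-phenylpiperidin-1-yl in its place; in this assay compound 2 gives 1110 nM, and the step of a 3.9-fold lower number from compound 1 to compound 2 (0.59 log units; beyond the scatter) is the only measured one in this set. Compound 3 `CC(C)c1c(C(=O)NCc2ccccn2)nn(-c2ccc(F)cc2)c1OC[C@@H](O)C[C@@H](O)CC(=O)O` carries a ((pyridin-2-yl)methyl)amino group on the same carbonyl carbon; in this assay compound 3 gives "not determined" (no result reported), so it stands without a number.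

Compound 4 `CC(C)c1c(C(=O)N(C)Cc2cccc(Cl)c2)nn(-c2ccc(F)cc2)c1OC[C@@H](O)C[C@@H](O)CC(=O)O` differs from compound 3 in one place: (3-chlorobenzyl)(methyl)amino in place of ((pyridin-2-yl)methyl)amino on a carbonyl carbon. Among the measured compounds shown here, no measured step bears directly on this change; the step from compound 1 to compound 2 concerns a different pair of groups and only shows that swapping the amide substituent can move the number modestly. With compound 3 lacking a value, the expectation for compound 4 can rest only on the range spanned by compound 1 and compound 2. Compound 4 is therefore estimated in this assay at 2000 nM, with a range from 500 nM to 8000 nM.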

Compound 4, half-maximal inhibitory concentration: 2120 nM
Compound 4: middle estimate off by 1.1-fold (0.03 log units), on the low side; the range from low to high includes it.
By their numbers in this assay, from the lowest: compounds 2 and 4 (each within the scatter of the next); then compound 1.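

With (3-chlorobenzyl)(methyl)amino on the carbonyl carbon, compound 4 shows that in this assay an amide nitrogen outside any ring can give a number level with that of the 3-phenylpiperidin-1-yl amide, the step being a 1.9-fold higher number from compound 2 to compound 4 (0.28 log units; within the scatter) and so no real difference between the two groups. Set against the 2-phenylpyrrolidin-1-yl amide, the same group gives a 2.0-fold lower number from compound 1 to compound 4 (0.31 log units; beyond the scatter), a modest change that only just clears the scatter and places compound 4 with compound 2 rather than with compound 1. Compound 3 has no number, so the step to compound 4 cannot be read, and no measurement offered here accounts for any of these differences.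

The compounds shown do not separate the part played by the chlorine from that of the methyl on the amide nitrogen, and a plain benzylamino group would be the direct comparison for both. On these data alone, how a morpholine or a carboxylic acid on this amide would read in this assay also remains open, as does the effect of the ((pyridin-2-yl)methyl)amino group.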